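The source may hold more compounds than are shown below. What is called first, only, known or untested is meant among the compounds shown, and "the series" means these compounds.

Compound 1, `Cc1cccc(Oc2cccc(COc3ccccc3CCC(=O)OCCCOP(=O)(O)OC[C@H](N)C(=O)O)c2)c1`, gives 0.29 in an assay on cells for activation of probable G-protein coupled receptor 34 (Mus musculus), with a stated time of 1 h; on this read-out higher numbers stand for larger maximal responses and lower numbers for smaller maximal responses.
Compound 2, `N[C@@H](COP(=O)(O)OCCCOC(=O)CCc1ccccc1OCc1cccc(Oc2cccc(Cl)c2)c1)C(=O)O`, gives 0.53 in this assay.
Compound 3, `N[C@@H](COP(=O)(O)OCCCOC(=O)CCc1ccccc1OCc1cccc(Oc2ccc(Br)cc2)c1)C(=O)O`, gives 0.97 in this assay.

Compound 3 stands highest of the three: compound 2 lies nearest, by a number 0.44 higher from compound 2 to compound 3 (beyond the scatter), and compound 1 furthest, by a number 0.68 higher from compound 1 to compound 3 (beyond the scatter); both steps go beyond the usual scatter. All three share one core and differ only in the aromatic ring that sits on an oxygen on an aromatic ring.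

Compound 4, `CCc1ccc(Oc2cccc(COc3ccccc3CCC(=O)OCCCOP(=O)(O)OC[C@H](N)C(=O)O)c2)cc1`, continues that series. It differs from compound 3 in a single place: ethyl in place of bromo on an aromatic carbon. Among the compounds with values here, no measured pair swaps bromo for ethyl directly, so the expectation must rest on neighbouring steps. The step a number 0.24 higher from compound 1 to compound 2 (beyond the scatter) shows that a halogen in place of an alkyl group on an aromatic carbon raised the maximal response, and the step a number 0.68 higher from compound 1 to compound 3 (beyond the scatter) shows the bromo-bearing ring well ahead of the methyl-bearing one. Reversing that direction, from bromo to ethyl, a drop is therefore expected, though the two steps disagree on how large it should be. For compound 4 the estimated value is 0.6, with a range from 0.3 to 0.95, which corresponds to an expected step of a number 0.37 lower from compound 3 to compound 4 (beyond the scatter).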

Compound 4, intrinsic activity: the largest response reached, as a fraction of the reference agonist's: 0.42
Beside the measured number, compound 4's estimate is 0.18 above it; the measured number falls inside the stated range.
By their numbers in this assay, from the lowest: compound 1; then compound 4; then compound 2; then compound 3.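

In this assay, compound 4 gives the first change made at the place held by the bromo of compound 3, on the aromatic carbon para to a large group, with that place itself kept: a number 0.55 lower from compound 3 to compound 4 (beyond the scatter). A group at this place therefore does not by itself bring a high maximal response, since the 4-ethylphenyl ring stands much closer to the 3-chlorophenyl and 3-methylphenyl rings than to the 4-bromophenyl ring, with a number 0.11 lower from compound 2 to compound 4 (beyond the scatter) and a number 0.13 higher from compound 1 to compound 4 (beyond the scatter), both modest steps. Nothing available here explains why bromo and ethyl differ so much at this place.

On these data alone, it remains open whether the high response belongs to bromo alone or extends to other groups at this place, and chloro or methyl there would help to separate the two possibilities. As far as these compounds go, it is also open how the response would move with a longer chain such as propyl, or with an amine or a carboxylic acid at the same carbon.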